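Swapping the cyano for an ester on the pyridine

This account rests on a few compounds, and the source may have more. Where it says the series, first, only, none or still open, it means among the compounds named here.

Of the compounds shown here, three have been measured in an assay for inhibition of Fatty-acid amide hydrolase 1 (Rattus norvegicus); a higher number here means a weaker inhibitor, a lower number a stronger inhibitor. Compound 1 `N#Cc1cccc(-c2cnc(C(=O)CCc3ccc(COc4ccccc4)cc3)o2)n1` gives 0.56 nM, compound 2 `N#Cc1cccc(-c2cnc(C(=O)CCc3ccc(-c4ccccc4)cc3)o2)n1` gives 2.9 nM, and compound 3 `O=C(CCc1ccc(Oc2ccccc2)cc1)c1ncc(C(F)(F)F)o1` gives 2 nM. Compound 2 thus shows the highest of the three numbers; its value and that of compound 3 lie within the scatter of each other, while the step of a 5.2-fold higher number from compound 1 to compound 2 (0.71 log units; beyond the scatter) lies beyond the scatter.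

Compound 4 `COC(=O)c1cccc(-c2cnc(C(=O)CCc3ccc(-c4ccccc4)cc3)o2)n1` differs from compound 2 at the far end of the molecule: methoxycarbonyl in place of cyano on an aromatic carbon. The change sits on an aromatic carbon of a six-membered aromatic ring with one nitrogen, next to the ring nitrogen, meta to a large group; cut one bond further out it reads 6-cyanopyridin-2-yl to 6-(methoxycarbonyl)pyridin-2-yl.

Within the data shown here, none of the measured steps touches this part of the structure. Among the measured compounds shown here, the only step in hand, the one from compound 1 to compound 2, concerns the group on the other aromatic ring, so it gives no direct guide. With nothing in this assay speaking for or against the exchange, the estimate for compound 4 in this assay is 3.5 nM, within 1 nM to 12 nM. That amounts to an expected step of a 1.2-fold higher number from compound 2 to compound 4 (0.08 log units; within the scatter), which is not beyond the scatter.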

Compound 4, inhibition constant: 1.2 nM
Estimate against measurement, compound 4: 2.9-fold (0.46 log units) above; low and high end bracket the measured number.
By their numbers in this assay, from the lowest: compound 1; then compounds 4, 3 and 2 (each within the scatter of the next, the first and the last beyond it).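

The change from 6-cyanopyridin-2-yl to 6-(methoxycarbonyl)pyridin-2-yl gives a 2.4-fold lower number from compound 2 to compound 4 (0.38 log units; beyond the scatter) in this assay, the first measured sign that the group at this position affects the number. With the phenyl group kept on the other aromatic ring, the nitrile is not needed here for a low number, and a methoxycarbonyl group of 4 heavy atoms can stand in place of a cyano group of 2 without any loss. No measurement shown here accounts for this step, so the pair records the size of the change and nothing about its origin.

As far as these compounds go, what stays open is whether the lower number belongs to the methoxycarbonyl group specifically or would also appear with a carboxylic acid, a primary amide or a longer ethyl ester at the same place. Among these compounds, it is also open whether the step from cyano to methoxycarbonyl would carry over to the core of compound 1, where phenoxymethyl stands on the other aromatic ring, as no pair with that group tests the exchange.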